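The source may report more compounds than this note shows. Statements on the series, on what has been measured and on what is new or still open speak of the compounds shown alone.

Measured so far in a functional assay on the whole organism (artery, strain albino) with Rattus norvegicus as the target, with a stated time of 360 min, at a dose of 10 mg/kg by the oral route; on this read-out higher numbers stand for more inhibition at the one dose given (going by the name of the read-out) and lower numbers for less inhibition:
compound 1 `COc1ccc(C2N=C(SCc3ccccc3)NC(C)=C2C(=O)Nc2ccc(Br)cc2)cc1` gives 18.6%
compound 2 `COc1ccc(C2N=C(SCc3cccc(Cl)c3)NC(C)=C2C(=O)Nc2ccc(Br)cc2)cc1` gives 39.7%
compound 3 `CC1=C(C(=O)Nc2ccc([N+](=O)[O-])cc2)C(c2ccc(Br)cc2)N=C(SCc2ccccc2Cl)N1` gives 13.9%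

Compound 3 holds the lowest of the three numbers; compound 1 lies within the scatter of it, while compound 2 lies beyond it. Going by the values given here, the single measured step is a number 21.1 percentage points higher from compound 1 to compound 2 (beyond the scatter), a change in the same part of the molecule that is altered here. Compound 4 `CC1=C(C(=O)Nc2ccc([N+](=O)[O-])cc2)C(c2ccc(Br)cc2)N=C(SCc2ccc(F)cc2)N1` differs from compound 3 by 4-fluorophenyl in place of 2-chlorophenyl on a saturated chain carbon bound to a sulfur. This is not the same change: the chlorine leaves rather than enters and fluorine arrives, so the measured step gives only a loose guide. For compound 4 the expected step is a number 4.1 percentage points higher from compound 3 to compound 4 (within the scatter), nothing beyond the scatter. Compound 4 is therefore estimated at 18%, between 5% and 35%, in this assay.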

Compound 4, a percentage reported as inhibition, in the whole organism at one dose (the size of the read-out at that dose, not a potency): 38.7%
Compound 4: the middle estimate sits 20.7 percentage points below what was measured; measured number outside the range, above it.
By their numbers in this assay, from the lowest: compounds 3 and 1 (each within the scatter of the next); then compounds 4 and 2 (each within the scatter of the next).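

In this assay, 4-fluorophenyl in place of 2-chlorophenyl on a saturated chain carbon bound to a sulfur gives a number 24.8 percentage points higher from compound 3 to compound 4 (beyond the scatter). This ring therefore moves the read-out beyond the scatter in a second setting as well, alongside a number 21.1 percentage points higher from compound 1 to compound 2 (beyond the scatter), and here with the halogen exchanged and its place on the ring altered in one step. No measurement offered here accounts for the rise.

On these data alone, whether the fluorine or the removal of the 2-chlorophenyl carries the step stays open. Also open, as far as these compounds go, is how a carboxylic acid on this ring, or a longer chain in place of the benzyl, would read.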